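Replacing one group on compound 2

The source may hold more compounds than are shown below. What is called first, only, known or untested is meant among the compounds shown, and "the series" means these compounds.

Measured so far (a functional assay (aorta) with Rattus norvegicus as the target; a higher number here means that more compound is needed for the effect, a lower number that less compound is needed):
compound 1 `CC(C)C[C@H](N)C(=O)Nc1cc2cc[nH]c(=O)c2cc1Cl` gives "not determined" (no result reported)
compound 2 `CC(C)[C@H](N)C(=O)Nc1cc2cc[nH]c(=O)c2cc1Cl` gives 500 nM

Going by the values given here, compound 2 holds the only number in this small set. Compound 1 has no result to compare it with, so compound 2 cannot yet be ranked as strong or weak within the series.

Compound 3 `CN1CCC(C(=O)Nc2cc3cc[nH]c(=O)c3cc2Cl)CC1` keeps the shared core and carries 1-methylpiperidin-4-yl in place of 1-amino-2-methylpropyl on a carbonyl carbon. Among the compounds with values here, no measured pair shows what a change at this place does in this assay, so the forecast rests on compound 2 with 500 nM alone and must stay loose. The expected shift (a 1.6-fold higher number from compound 2 to compound 3 (0.20 log units; within the scatter)) stays within the usual scatter, leaning slightly toward more compound being needed. For compound 3 the estimate is 800 nM (expected range 200 nM to 3000 nM).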

Compound 3, half-maximal effective concentration: 250 nM
Estimate against measurement, compound 3: 3.2-fold (0.51 log units) above; the measured number falls inside the stated range.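

Going by these compounds alone, this is the first step at this place on the carbonyl carbon, and in this assay replacing 1-amino-2-methylpropyl with 1-methylpiperidin-4-yl gives a 2.0-fold lower number from compound 2 to compound 3 (0.30 log units; within the scatter). So compound 2 and compound 3 cannot be told apart here, even though the open-chain group gives way to a larger six-membered ring, and the hydrogen-bond donor and defined stereocentre of the leaving group are gone. No measurement available here explains this outcome.

The compounds shown leave open whether the ring nitrogen or its methyl group matters, which a cyclohexyl group or an unsubstituted piperidin-4-yl group would test. They also leave open how a group with a carboxylic acid would behave at this place, and one tolerated swap does not define how much change the position accepts.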